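This account rests on a few compounds, and the source may have more. Where it says the series, first, only, none or still open, it means among the compounds named here.

Measured compounds:

Compound 1, `Cc1cc(NC(=S)Cn2nnc(-c3ccccc3)n2)n(C2CCCCC2)n1`: 80%
Compound 2, `Cc1cc(NC(=O)Cn2nnc(-c3ccccc3)n2)n(CC2CCCCC2)n1`: 77%
Compound 3, `Cc1cc(NC(=O)Cn2nnc(-c3cccnc3)n2)n(C2CCCCC2)n1`: 96%

Of the compounds shown here, three sharing one core have been measured in an assay on HEK293 cells for activation of Kir3.1/Kir3.2 (Homo sapiens), read by thallium flux; on this read-out lower numbers stand for smaller maximal responses and higher numbers for larger maximal responses. Compound 3 gives 96%, the highest of the three numbers. Compound 1, with 80%, stands beyond the scatter below it, and compound 2, with 77%, stands still further below, also beyond the scatter. No two of these compounds differ in only one place, so no single structural change has yet been tied to a change in the read-out.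

The next compound, compound 4 `COc1ccc(-c2nnn(CC(=O)Nc3cc(C)nn3C3CCCCC3)n2)cc1`, differs from compound 3 in one place: 4-methoxyphenyl in place of pyridin-3-yl on an aromatic carbon. Going by the values given here, since the measured compounds give no step for this kind of change, the expectation rests on the spread of values seen so far. A small drop is expected, roughly at the edge of the scatter, which is what a number 11 percentage points lower from compound 3 to compound 4 (beyond the scatter) means. The estimate for compound 4 in this assay is 85%, with a likely range from 65% to 100%.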

Compound 4, largest response reached (Emax), in percent of the reference or control that the assay uses: 90%
For compound 4 the middle estimate is 5 percentage points below the measured one; low and high end bracket the measured number.
By their numbers in this assay, from the lowest: compounds 2, 1, 4 and 3 (each within the scatter of the next, the first and the last beyond it).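

In this assay, placing 4-methoxyphenyl in position of pyridin-3-yl on the aromatic carbon of the five-membered ring gives a number 6 percentage points lower from compound 3 to compound 4 (within the scatter). Going by these compounds alone, this is the first change that can be read in one place, and it shows that this carbon can carry a ring of carbon only, with a methoxy group attached, and keep the maximal response within the usual scatter. The ring nitrogen of pyridin-3-yl is therefore not required for a response at this level, though no measurement here explains why the two groups read alike.

Still open, on these data alone, is how a carboxylic acid or an amine on the phenyl ring would read in place of the methoxy group. Also open, as far as these compounds go, is whether a non-aromatic ring such as piperidine at this carbon would hold the response.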